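The source may report more compounds than this note shows. Statements on the series, on what has been measured and on what is new or still open speak of the compounds shown alone.

Measured compounds:
Compound 1 `CCCCC(=O)Nc1ccc(C2=NNC(=O)CC2)cc1` gives 2.64 ug/mL in a functional assay for inhibition, with Homo sapiens as the target; on this read-out higher numbers stand for an effect only at larger amounts of compound and lower numbers for an effect already at smaller amounts.
Compound 2 `CC(=O)Nc1ccc(C2=NN(C)C(=O)CC2)cc1` reaches only the limit of the assay, > 46.4 ug/mL, in this assay; this is a limit and not a number.
Compound 3 `CC(=O)Nc1ccc(C2=NNC(=O)C(C)C2)cc1` gives 46.4 ug/mL in this assay.

Among the two numbers obtained, compound 1 has the lowest, and compound 3 is nearest to it, at a distance that lies beyond the usual scatter of repeated measurements. The third value, that of compound 2, is only a limit of > 46.4 ug/mL in this assay, at which 1 of the 3 values shown sits, and therefore cannot be ordered against the other two. Compounds 2 and 3 differ from compound 1 in more than one place, so none of these pairs defines a single step.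

The unmeasured compound 4 `C[N+]1(CC(=O)Nc2ccc(C3=NNC(=O)CC3)cc2)CCCC1` differs from compound 1 in one place: a group of 6 heavy atoms (5 carbon, 1 nitrogen; one five-membered non-aromatic ring with 1 hetero atom) in place of a group of 3 heavy atoms (3 carbon; no ring), on a saturated chain carbon bound to a carbonyl carbon. Among the measured compounds shown here, no step of this kind has been measured here, so its size can only be expected. The charged group is expected to move the value in this assay upward, toward a weaker effect, by an amount beyond the scatter, though a limit cannot be excluded. Compound 4 is therefore estimated at 15 ug/mL, between 3 ug/mL and 46.4 ug/mL, which means an expected step of a 5.7-fold higher number from compound 1 to compound 4 (0.75 log units; beyond the scatter).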

Compound 4, half-maximal effective concentration: > 46.4 ug/mL
Compound 4 gave a limit, no number; the forecaster's own chance of this, stated with the estimate: 30%; at least 3.0-fold (0.49 log units) between middle value and limit.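

On the saturated chain carbon bound to a carbonyl carbon, the core of compound 1 proves sensitive to what is attached: in this assay, replacing propyl with the five-membered non-aromatic ring group of net charge +1 gives an at least 17-fold higher number from compound 1 to compound 4 (1.24 log units; beyond the scatter). Compound 4 stands at > 46.4 ug/mL, which is a limit and not a number. This is the first single step among the compounds shown, and it is the first to show that a change at this place alone can take the core of compound 1 from a measured value to the end of the read-out, though its full size stays unknown because the read-out stops at a limit: the limit of > 46.4 ug/mL in this assay, at which 2 of the 4 values shown sit.

The step changes the size of the group, the ring and the net charge all at once, so the compounds shown cannot say which of these matters, or whether any of them does so alone. They also leave open how a longer chain, such as hexyl, or an uncharged tertiary amine or a carboxylic acid on the same chain carbon would read in this assay.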